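Hydrazone series: hydroxy for bromo on the aromatic carbon

A few compounds are considered here, and "the series" means these few. Any claim that something is new, unique, unknown or untested is made for them only; others in the source may bear on it.

Measured compounds:
compound 1 `O=C(N/N=C/c1ccccc1Cl)c1cnccn1`: 66%
compound 2 `O=C(N/N=C/c1ccccc1Br)c1cnccn1`: 100%

In an ADME assay on J774 cells (Mus musculus) for cytotoxicity, read by MTT assay, with a stated time of 48 h, tested at 100 ug/mL (a higher number here means a weaker effect of the compound at the concentration tested, a lower number a stronger effect), compound 2 gives 100%, the highest of the two numbers; compound 1 gives 66%. For the measured compounds named here, the only measured step is a number 34 percentage points higher from compound 1 to compound 2 (beyond the scatter). Compound 3 `O=C(N/N=C/c1ccccc1O)c1cnccn1` differs from compound 2 by hydroxy in place of bromo on an aromatic carbon. Going by the values given here, no measured step exchanges a halogen for hydroxy, so that step bears on this change only loosely, and the direction is open. The expected step for compound 3 is a number 18 percentage points lower from compound 2 to compound 3 (beyond the scatter), a moderate fall from compound 2. Compound 3 is therefore estimated at 82%, in the range 58% to 100%.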

Compound 3, a percentage reported as activity, at one concentration (the size of the read-out at that concentration, not a potency): 0.3%
Compound 3: the middle estimate sits 81.7 percentage points above what was measured, and the stated range ends above it.
By their numbers in this assay, from the lowest: compound 3; then compound 1; then compound 2.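

In this assay, the group on this aromatic carbon proves able to move the read-out far more than the halogen exchange suggested: hydroxy in place of bromo gives a number 99.7 percentage points lower from compound 2 to compound 3 (beyond the scatter), and hydroxy in place of chloro gives a number 65.7 percentage points lower from compound 1 to compound 3 (beyond the scatter). Compound 3 therefore stands apart from both halogen compounds, with hydroxy adding a hydrogen-bond donor and acceptor that bromo lacks. Nothing available accounts for the size of these steps. Still open, going by these compounds, is whether an amine or a methoxy group on this aromatic carbon would read like hydroxy or like the halogens.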